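Side-chain Swap on a Shared Core: Compound 3 Awaits Measurement

The source may hold more compounds than are shown below. What is called first, only, known or untested is meant among the compounds shown, and "the series" means these compounds.

In a functional assay on the whole organism (Tail, strain ICR) with Mus musculus as the target, in the tail flick test, with a stated time of 30 min, at a dose of 25 umol/kg by the oral route (a lower number here means a weaker effect, a higher number a stronger effect of the compound at the dose given), compound 2 `CC[C@H](C)[C@H](NC(=O)CN(c1ncnc2c1ncn2C1CCCCO1)C1CC1)C(=O)OCc1ccccc1` gives 25.6%. Among the compounds with values here, that puts compound 2 at the top of the two numbers measured so far, but only by a gap within the scatter: compound 1 `N=C(N)NCCC[C@H](NC(=O)CN(c1nc(Cl)nc2[nH]cnc12)C1CC1)C(=O)OCc1ccccc1` gives 23.2% in this assay, so the two cannot be ordered. Within the data shown here, compound 1 and compound 2 differ in more than one place, and no single step between them can be read.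

Compound 3 `NC(=O)C[C@H](NC(=O)CN(c1ncnc2c1ncn2C1CCCCO1)C1CC1)C(=O)OCc1ccccc1` has not yet been measured. It keeps the core of compound 2 and differs in one place: carbamoylmethyl in place of sec-butyl on a saturated chain carbon bound to an amide-type nitrogen and a carbonyl carbon. Among the measured compounds shown here, no measured pair shows a step of this kind, so the expectation rests on the two numbers alone; a shift in this assay of no more than the scatter, in either direction, seems the likeliest outcome. Compound 3 is therefore estimated at 20% in this assay, with a range from 8% to 35%. This estimate means an expected step of a number 5.6 percentage points lower from compound 2 to compound 3 (within the scatter), within the scatter.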

Compound 3, a percentage reported as activity, at one dose (the size of the read-out at that dose, not a potency): 34.5%
The estimate for compound 3 lay 14.5 percentage points below the measured number; measured number inside the range.
By their numbers in this assay, from the lowest: compounds 1, 2 and 3 (each within the scatter of the next, the first and the last beyond it).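

In this assay, within the data shown here, the swap of sec-butyl for carbamoylmethyl on a saturated chain carbon bound to an amide-type nitrogen and a carbonyl carbon gives the first step that can be read at this place: a number 8.9 percentage points higher from compound 2 to compound 3 (within the scatter), so the two compounds cannot be ordered. The entering group brings 1 hydrogen-bond donor and 1 hydrogen-bond acceptor where the leaving group has neither, and at this dose the read-out does not separate the two side chains. Nothing in hand bears on the cause of this step.

Going by these compounds, whether another group at this place, such as a primary amine, a carboxylic acid or a longer chain, would move the read-out beyond the scatter remains open. So does whether the same swap would give a similar step on the core of compound 1.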